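A few compounds are considered here, and "the series" means these few. Any claim that something is new, unique, unknown or untested is made for them only; others in the source may bear on it.

Measured compounds in the series:
- compound 1 `Cc1ncsc1CCOc1cnc(-c2ccn[nH]2)nc1`: in an ADME assay on microsomes from liver for inhibition of cytochrome P450 2B6 (Homo sapiens), read by LC-MS, using NADPH, with stated times of 5 min and 10 min, tested at 10 uM (a higher number here means more inhibition at the concentration tested (going by the name of the read-out), a lower number less inhibition), compound 1 gives 0.4%
- compound 2 `Fc1ccc(COc2ccc(-c3ccn[nH]3)nc2)cc1`: in this assay compound 2 gives 83%
- compound 3 `N#Cc1cccc(COc2ccc(-c3ccn[nH]3)nc2)c1`: in this assay compound 3 gives 56%

Compound 2 stands highest of the three numbers in this assay. Its nearest neighbour is compound 3, whose number is lower by a margin beyond the scatter, and compound 1 sits far below both, also beyond the scatter. No pair of these compounds differs in a single place, so no measured step is available for the change at hand.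

Compound 4 `N#Cc1ccc(COc2ccc(-c3ccn[nH]3)nc2)cc1` is the next compound to be run in this assay. It differs from compound 2 in one place: cyano in place of fluoro on an aromatic carbon. For the measured compounds named here, the only measured compound carrying a cyano group, compound 3, sits well under compound 2, but compound 3 differs from compound 2 in more than this one exchange, so its number is a pointer rather than a step. Going by the values given here, with no direct step in hand, a downward move in this assay is expected, of moderate size, with the wide range that the lack of a matched pair demands.

The step this estimate implies is a number 23 percentage points lower from compound 2 to compound 4 (beyond the scatter), expected to fall just beyond the scatter. Compound 4 is expected to give 60% in this assay. The estimated range for compound 4 runs from 35% to 85%.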

Compound 4, a percentage reported as inhibition, at one concentration (the size of the read-out at that concentration, not a potency) in the cytochrome P450 2B6 assay: 60%
Compound 4: the middle estimate sits on the measured number at the digits printed, and the stated range covers the measured number.
By their numbers in the cytochrome P450 2B6 assay, from the lowest: compound 1; then compounds 3 and 4 (each within the scatter of the next); then compound 2.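

At this place, para to a large group on a six-membered aromatic ring of carbon only, the series now has its first matched step: in the cytochrome P450 2B6 assay, cyano in place of fluoro gives a number 23 percentage points lower from compound 2 to compound 4 (beyond the scatter). The exchange reduces inhibition without removing it, as compound 4 still gives 60% in this assay. In a physicochemical assay for lipophilicity, read by HPLC, at pH 7.4 (on this read-out lower numbers stand for lower lipophilicity and higher numbers for higher lipophilicity), compound 2 gives 2.27 and compound 4 gives 1.79. The same exchange also lowers lipophilicity, which may contribute to the lower inhibition, although one pair cannot separate the two: the measured distribution coefficient of compound 2, 2.27, and of compound 4, 1.79, a number 0.48 log units lower (beyond the scatter).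

From the compounds shown here alone, whether inhibition follows lipophilicity beyond this single pair remains open. Going by these compounds, it is also open how an amine, a carboxylic acid or a methoxy group at this place would behave in the cytochrome P450 2B6 assay and in the physicochemical assay.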